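Switching the aryl group on a urea nitrogen

A few compounds are considered here, and "the series" means these few. Any claim that something is new, unique, unknown or untested is made for them only; others in the source may bear on it.

Measured so far:
- compound 1 `COc1cc(Cl)cc(-c2nn(-c3cccc(NC(=O)c4ccc(Cl)c(Cl)c4)c3)cc2-c2ccncc2)c1`: 33.9%
- compound 2 `COc1cc(Cl)cc(-c2nn(-c3cccc(NC(=O)Nc4ccc(Cl)c(Cl)c4)c3)cc2-c2ccncc2)c1`: -21%

In a functional assay on MDA-MB-231 cells (Homo sapiens) for inhibition, read by sulforhodamine B assay, with a stated time of 48 h, tested at 10 uM (a lower number here means a stronger effect, a higher number a weaker effect of the compound at the concentration tested), compound 2 gives -21%, the lowest of the two numbers, with compound 1 the nearest at 33.9%. Among the measured compounds shown here, the only measured step, a number 54.9 percentage points lower from compound 1 to compound 2 (beyond the scatter), concerns a change on the carbonyl carbon and was large. Compound 3 `COc1cc(Cl)cc(-c2nn(-c3cccc(NC(=O)Nc4cccc(C(F)(F)F)c4)c3)cc2-c2ccncc2)c1` differs from compound 2 elsewhere: 3-(trifluoromethyl)phenyl in place of 3,4-dichlorophenyl on an amide-type nitrogen. For the measured compounds named here, no measured pair shows this kind of exchange on the amide-type nitrogen, so the one known step gives no direct guide; it tells only that the shared core of compound 2 tolerates a strongly negative reading when the urea is present. Both compound 2 and compound 3 keep that urea, so a change no larger than the scatter is expected, as a number 11 percentage points higher from compound 2 to compound 3 (beyond the scatter). On that basis compound 3 is expected to give about -10% in this assay, with a range from -40% to 25%.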

Compound 3, a percentage reported as activity, at one concentration (the size of the read-out at that concentration, not a potency): -9.21%
Beside the measured number, compound 3's estimate is 0.8 percentage points below it; low and high end bracket the measured number.
By their numbers in this assay, from the lowest: compound 2; then compound 3; then compound 1.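

In this assay, the aryl group on the amide-type nitrogen of the urea proves to matter, though modestly: 3-(trifluoromethyl)phenyl in place of 3,4-dichlorophenyl gives a number 11.8 percentage points higher from compound 2 to compound 3 (beyond the scatter) and the reading stays negative. The large gap to the amide also survives this exchange, with a number 43.1 percentage points lower from compound 1 to compound 3 (beyond the scatter) even though that step alters both the linking group and the aryl group, so the low reading of the urea compounds is now seen with two different aryl groups rather than one. Nothing measured here explains why the two aryl groups differ, or what a negative reading reflects in these cells.

Still open, from the compounds shown here alone, is how far this position can be pushed, for example whether a urea carrying a plain phenyl, a pyridine, a carboxylic acid, an amine or a longer alkyl chain in place of the aryl group would keep the reading this low. The compounds shown also leave open how an amide carrying 3-(trifluoromethyl)phenyl would read, and that comparison would separate the effect of the urea from that of the aryl group.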